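The compounds below may be only part of what the source reports. "The series", "measured", "known", "first", "only" and "open" are said of these compounds alone.

Measured in an ADME assay on CCRF-HSB-2 cells (Homo sapiens) for cytotoxicity, with a stated time of 7 days; on this read-out higher numbers stand for lower toxicity in this test and lower numbers for higher toxicity in this test:

- compound 1 `C=CCOc1nc(N)nc2c1ncn2/C=C1/CC1(CO)CO`: > 20000 nM (a limit)
- compound 2 `CC(C)CNc1nc(N)nc2c1ncn2/C=C1/CC1(CO)CO`: > 20000 nM (a limit)
- compound 3 `Nc1nc(SC2CCCC2)c2ncn(/C=C3/CC3(CO)CO)c2n1`: 91000 nM

Of these three, only compound 3 has a number, 91000 nM. The other two results are limits of the assay and not numbers, so compound 3 cannot be ranked against them.

The next compound to be tested, compound 4 `Nc1nc(SCc2ccccc2)c2ncn(/C=C3/CC3(CO)CO)c2n1`, differs from compound 3 in one place: benzyl in place of cyclopentyl on a sulfur, (benzyl in place of cyclopentyl on a sulfur).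

Two measured steps end at compound 3: a step that the limit leaves unreadable from compound 1 to compound 3 and a step that the limit leaves unreadable from compound 2 to compound 3. A third step joins the other two compounds: a step that the two limits leave unreadable from compound 1 to compound 2. None of these has a readable size because of the limit of > 20000 nM in this assay, at which 2 of the 3 values shown sit. Going by the values given here, none of them swaps one group on a sulfur for another, so the data offer no measured precedent for this change.

With no size to carry over, no step beyond the usual scatter is expected in this assay, and no direction can be argued. The expectation therefore stays anchored on compound 3 at 91000 nM. The expected change is a 1.3-fold lower number from compound 3 to compound 4 (0.11 log units; within the scatter). For compound 4 the estimated value is 70000 nM, with an expected range of 20000 nM to 200000 nM.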

Compound 4, half-maximal cytotoxic concentration: > 100000 nM
Compound 4: only a limit was reported (the forecaster's own chance of this, stated with the estimate: 35%); middle value at least 1.4-fold (0.15 log units) away from the limit.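

In this assay compound 4 gives > 100000 nM, which is a limit of the assay and not a number. This is the only swap of one group on a sulfur for another among these compounds, and it reads as an at least 1.0-fold higher number from compound 3 to compound 4 (0.04 log units; that floor lies within the scatter). Benzyl in place of cyclopentyl on this sulfur, with the rest of the molecule unchanged, therefore gives no sign of a lower number in this test, but how far the number rises stays unknown, and the steps to compound 4 from compound 1 and from compound 2 cannot be read: the limit of > 20000 nM in this assay, at which 2 of the 4 values shown sit.

What the compounds shown leave open is whether any group on this sulfur brings the read-out of this assay down, for example a benzyl carrying a fluorine on its ring, a longer chain, or a chain ending in an amine or a carboxylic acid. Also open, as far as these compounds go, is how benzylsulfanyl compares with isobutylamino or allyloxy on the same aromatic carbon, since each of these three compounds stands at a limit of the assay.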